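Shortening the hydroxamic acid linker by one carbon

A few compounds are considered here, and "the series" means these few. Any claim that something is new, unique, unknown or untested is made for them only; others in the source may bear on it.

Measured so far:
- compound 1, `CC(C)c1cc(-c2n[nH]c(=O)n2-c2cccc(C(=O)NCCCCCCC(=O)NO)c2)c(O)cc1O`: 4600 nM
- compound 2, `CC(C)c1cc(-c2n[nH]c(=O)n2-c2ccc(C(=O)NCCCC(=O)NO)cc2)c(O)cc1O`: 4600 nM

Both compounds carry the same core and end in a hydroxamic acid on a saturated chain. In a functional assay on HEL cells (Homo sapiens) for inhibition (a lower number here means a stronger inhibitor, a higher number a weaker inhibitor), compound 1 gives 4600 nM, and in this assay compound 2 gives 4600 nM. Compound 1 therefore stands level with compound 2 at the digits shown; the two values lie within the usual scatter of this assay, so no order between them can be read.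

The unmeasured compound 3, `CC(C)c1cc(-c2n[nH]c(=O)n2-c2cccc(C(=O)NCCCCCC(=O)NO)c2)c(O)cc1O`, differs from compound 1 in one place: hydroxycarbamoyl in place of (hydroxycarbamoyl)methyl on a saturated chain carbon, five bonds along the chain from an amide-type nitrogen. In plain terms the chain between the amide-type nitrogen and the hydroxamic acid is one carbon shorter.

For the measured compounds named here, no step between measured compounds is available to anchor this change, and the two values known are identical. The step from compound 1 to compound 3 is expected to be small, no change at the digits printed from compound 1 to compound 3 (within the scatter), most likely none beyond the scatter, with no clear direction favoured. Compound 3 is therefore estimated at 4600 nM in this assay, with a range of 1500 nM to 14000 nM.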

Compound 3, half-maximal inhibitory concentration: 4600 nM
Estimate against measurement, compound 3: no gap at the digits printed; low and high end bracket the measured number.
By their numbers in this assay, from the lowest: compounds 1, 2 and 3 (each within the scatter of the next).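

For the compounds shown here, the pair of compound 1 and compound 3 gives the first direct reading of a single change: in this assay, swapping (hydroxycarbamoyl)methyl for hydroxycarbamoyl on a saturated chain carbon, five bonds along the chain from an amide-type nitrogen, gives no change at the digits printed from compound 1 to compound 3 (within the scatter) and leaves the rest of the molecule untouched. The earlier compounds shown here could not show this, as no two of them differed in one place only; now it is clear that, on this chain, this trimming of the end of the chain leaves no mark that rises above the scatter of the read-out. No measurement shown here bears on why the result comes out this way.

The compounds shown leave open whether the same flat response would hold for a longer chain than that of compound 1, or for a much shorter chain on this same attachment, as a single step cannot define a trend. They also leave open what would happen with a carboxylic acid or a primary amide at the chain end in place of the hydroxamic acid.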